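Swapping the nitro group for bromine on compound 3

A few compounds are considered here, and "the series" means these few. Any claim that something is new, unique, unknown or untested is made for them only; others in the source may bear on it.

Measured compounds in a functional assay on K562 cells (Homo sapiens) for inhibition; on this read-out higher numbers stand for weaker inhibition and lower numbers for stronger inhibition:
- compound 1 `O=C1C=CC(OCC(F)(F)F)N1c1ccc(C(F)(F)F)cc1`: 13100 nM
- compound 2 `O=C1C=CC(OCC(F)(F)F)N1c1ccccc1`: 24600 nM
- compound 3 `O=C1C=CC(OCC(F)(F)F)N1c1ccc([N+](=O)[O-])cc1`: 1530 nM

Compound 3 gives the lowest number of the three in this assay. Its nearest neighbour is compound 1, and the step of an 8.6-fold lower number from compound 1 to compound 3 (0.93 log units; beyond the scatter) is beyond the scatter. Compound 2 lies furthest away, and the step of a 16-fold lower number from compound 2 to compound 3 (1.21 log units; beyond the scatter) is larger still. The step of a 1.9-fold higher number from compound 1 to compound 2 (0.27 log units; within the scatter) is within the scatter, so those two compounds cannot be ranked against each other.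

Compound 4 `O=C1C=CC(OCC(F)(F)F)N1c1ccc(Br)cc1` differs from compound 3 in one place: bromo in place of nitro on an aromatic carbon. The two steps that bear on this change both lead into compound 3, an 8.6-fold lower number from compound 1 to compound 3 (0.93 log units; beyond the scatter) and a 16-fold lower number from compound 2 to compound 3 (1.21 log units; beyond the scatter), and both show that the nitro group goes with a markedly lower number than either trifluoromethyl or hydrogen at that carbon. Among the compounds with values here, no measured compound carries bromine there, so the direction is estimated from those two steps only.

Compound 4 is therefore expected to give a higher number than compound 3, with an estimated step of a 6.5-fold higher number from compound 3 to compound 4 (0.82 log units; beyond the scatter) in this assay. The estimate for compound 4 is 10000 nM, with a range from 3000 nM to 30000 nM.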

Compound 4, half-maximal inhibitory concentration: 3270 nM
For compound 4 the middle estimate is 3.1-fold (0.49 log units) above the measured one; measured number inside the range.
By their numbers in this assay, from the lowest: compound 3; then compound 4; then compounds 1 and 2 (each within the scatter of the next).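

In this assay the low numbers at this aromatic carbon do not belong to the nitro group alone: bromo also parts clearly from hydrogen (a 7.5-fold lower number from compound 2 to compound 4 (0.88 log units; beyond the scatter)) and from trifluoromethyl (a 4.0-fold lower number from compound 1 to compound 4 (0.60 log units; beyond the scatter)). The nitro group still keeps an edge over bromo, but that gap is the smallest of the three new steps (a 2.1-fold higher number from compound 3 to compound 4 (0.33 log units; beyond the scatter)) and lies only just beyond the scatter. The hydrogen-bond acceptors and the double bond that leave with the nitro group are therefore not required for a number well below those of compound 1 and compound 2.

From the compounds shown here alone, whether chloro, a nitrile or an amine at this carbon would join bromo and the nitro group, or fall with hydrogen and trifluoromethyl, stays open. No measurement shown here accounts for this order of the groups.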